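Bromo added to the pyridine of a piperazine arylpiperazine

The compounds below may be only part of what the source reports. "The series", "measured", "known", "first", "only" and "open" are said of these compounds alone.

For the measured compounds named here, compound 3 `Cn1c(=O)cnn(CCCCN2CCN(c3ccccn3)CC2)c1=O` sits second highest of the three numbers so far in an assay for displacement of a labelled ligand from Adrenergic receptor alpha-1 (Homo sapiens); on this read-out higher numbers stand for weaker inhibition and lower numbers for stronger inhibition: compound 3 gives 262 nM. Its nearest neighbour is compound 1 `CN(C)c1ccccc1N1CCN(CCCCn2ncc(=O)n(C)c2=O)CC1`, which in this assay gives 350 nM, a gap that is a 1.3-fold lower number from compound 1 to compound 3 (0.13 log units; within the scatter) and so within the scatter. Further away is compound 2 `Cn1c(=O)cnn(CCCCN2CCN(c3ccccc3)CC2)c1=O`, which in this assay gives 64 nM; the step of a 4.1-fold higher number from compound 2 to compound 3 (0.61 log units; beyond the scatter) lies beyond the scatter, as does a 5.5-fold lower number from compound 1 to compound 2 (0.74 log units; beyond the scatter).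

Compound 4 `Cn1c(=O)cnn(CCCCN2CCN(c3cccc(Br)n3)CC2)c1=O` differs from compound 3 in one place: bromo in place of hydrogen on an aromatic carbon. Going by the values given here, none of the measured steps adds a bromo group, so no direct precedent exists. Among the compounds with values here, the two steps that touch the aryl ring on the piperazine, a 5.5-fold lower number from compound 1 to compound 2 (0.74 log units; beyond the scatter) and a 4.1-fold higher number from compound 2 to compound 3 (0.61 log units; beyond the scatter), both moved the number by modest amounts, and the one step that removed a substituent from that ring, from compound 1 to compound 2, lowered the number. Adding a substituent at the pyridine is therefore expected to leave the number roughly where compound 3 stands or push it somewhat higher, with the step of a 1.2-fold higher number from compound 3 to compound 4 (0.09 log units; within the scatter) expected to stay close to the scatter. Compound 4 is estimated at 320 nM in this assay, within a range from 100 nM to 1000 nM.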

Compound 4, inhibition constant: > 10000 nM
Compound 4: no number, only a limit; the forecaster's own chance of this, stated with the estimate: 3%; middle value at least 31-fold (1.49 log units) from the limit.
By their numbers in this assay, from the lowest: compound 2; then compounds 3 and 1 (each within the scatter of the next). At a limit, above all of these: compound 4.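

In this assay, the earlier changes to the aryl group on the piperazine gave only modest steps, yet bromo, one heavy atom, placed next to the ring nitrogen of the pyridine gives an at least 38-fold higher number from compound 3 to compound 4 (1.58 log units; beyond the scatter). The gap is just as clear against the two other aryl groups, with an at least 150-fold higher number from compound 2 to compound 4 (2.19 log units; beyond the scatter) and an at least 28-fold higher number from compound 1 to compound 4 (1.45 log units; beyond the scatter), so in this assay 6-bromopyridin-2-yl stands apart from pyridin-2-yl, phenyl and 2-(dimethylamino)phenyl alike. The reading for compound 4 is a limit and not a number: the limit of > 10000 nM in this assay, at which 1 of the 4 values shown sits.

The compounds shown leave open whether this steep rise belongs to bromo itself or to any group at this carbon, a question that chloro, methyl or methoxy in its place could settle. They also leave open whether bromo at another carbon of the pyridine, or on the phenyl of compound 2, would give a similar step, and they offer no cause for the change.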